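A few compounds are considered here, and "the series" means these few. Any claim that something is new, unique, unknown or untested is made for them only; others in the source may bear on it.

Measured compounds in hand:

- compound 1, `C[S+]([O-])c1nc2ccccn2c(=N)c1S(=O)(=O)c1ccccc1`: 250 nM
- compound 2, `CSc1nc2ccc(F)cn2c(=N)c1S(=O)(=O)c1ccccc1`: 28 nM
- compound 3, `CSc1nc2ccc(Cl)cn2c(=N)c1S(=O)(=O)c1ccccc1`: 28 nM

All three were run in an assay on HeLa cells for displacement of a labelled ligand from 5-hydroxytryptamine receptor 6 (Homo sapiens); a lower number here means a stronger inhibitor, a higher number a weaker inhibitor. Compound 3 stands level with compound 2 at the digits given, and the two together show the lowest numbers of the set; the difference between them lies within the scatter, so no order between compound 2 and compound 3 can be read from it. Compound 1 is the furthest away, with 250 nM, a higher number that lies beyond the scatter, although compound 1 also differs from compound 3 in more than one place, so the gap cannot be assigned to a single change.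

The next compound, compound 4, `CSc1nc2ccc(Br)cn2c(=N)c1S(=O)(=O)c1ccccc1`, follows from compound 3 by a single change: bromo in place of chloro on an aromatic carbon. Going by the values given here, the one measured step that bears on this is the exchange of one halogen for another at the same place, no change at the digits printed from compound 2 to compound 3 (within the scatter), which produced no change within the scatter. On that basis the step from compound 3 to compound 4 is expected to be no change at the digits printed from compound 3 to compound 4 (within the scatter), that is, no movement beyond the scatter in either direction. Compound 4 is therefore estimated at 28 nM, with a range from 12 nM to 65 nM.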

Compound 4, half-maximal inhibitory concentration: 56 nM
Compound 4: middle estimate off by 2.0-fold (0.30 log units), on the low side, and the stated range covers the measured number.
By their numbers in this assay, from the lowest: compounds 2, 3 and 4 (each within the scatter of the next); then compound 1.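

With bromo on this aromatic carbon, two atoms from the ring nitrogen, this assay gives a 2.0-fold higher number from compound 3 to compound 4 (0.30 log units; within the scatter) and a 2.0-fold higher number from compound 2 to compound 4 (0.30 log units; within the scatter), so a third halogen now stands with the fluoro and chloro compounds and the earlier single exchange is no longer the only one at this place. Fluoro, chloro and bromo therefore lie within the scatter of one another in compounds 2, 3 and 4, and no order among these three halogens can be read from the numbers, though the pattern extends only to these three compounds. Nothing available here bears on why the three halogens give numbers this close.

Going by these compounds, whether the same holds beyond halogens at this place remains open, for instance with methoxy, nitrile, trifluoromethyl or an amine there, or with iodo as a further halogen. Compound 1 carries no halogen at this place but also differs from compounds 2, 3 and 4 in a second place, so what any halogen contributes against plain hydrogen cannot be read from the compounds shown.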